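This account rests on a few compounds, and the source may have more. Where it says the series, first, only, none or still open, it means among the compounds named here.

Series notes. Of the compounds shown here, three of the shared core have been measured in an ADME assay on PC-3 cells (Homo sapiens) for cytotoxicity, read by WST assay, tested at 100 uM; a lower number here means less inhibition, a higher number more inhibition at the concentration tested (going by the name of the read-out). Compound 1 `N#Cc1cccc(C(=O)N2CCCC(C(=O)Nc3ccc(Cl)cc3)C2)c1` gives 0%. Compound 2 `O=C(Nc1ccc(Cl)cc1)C1CCCN(C(=O)c2cccc(-c3nccs3)c2)C1` gives 32%. Compound 3 `Cc1nc(-c2cccc(C(=O)N3CCCC(C(=O)Nc4ccc(Cl)cc4)C3)c2)cs1` gives 1%. Among the three numbers compound 3 stands second highest; its nearest neighbour is compound 1, with a number 1 percentage points higher from compound 1 to compound 3 (within the scatter), and its furthest is compound 2, with a number 31 percentage points lower from compound 2 to compound 3 (beyond the scatter).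

Compound 4 `CCN(CC)S(=O)(=O)c1cccc(C(=O)N2CCCC(C(=O)Nc3ccc(Cl)cc3)C2)c1` has not yet been measured in this assay. It differs from compound 3 in one place: diethylsulfamoyl in place of 2-methyl-1,3-thiazol-4-yl on an aromatic carbon. For the measured compounds named here, no measured step introduces a diethylsulfamoyl group, so the exchanges at the same aromatic carbon are the only guide. Cyano to 1,3-thiazol-2-yl gave a number 32 percentage points higher from compound 1 to compound 2 (beyond the scatter), whereas cyano to 2-methyl-1,3-thiazol-4-yl gave a number 1 percentage points higher from compound 1 to compound 3 (within the scatter). Two of the three measured groups at this aromatic carbon leave the read-out near zero and only one raises it. Compound 4 is therefore expected to stay low, with an estimated step of a number 7 percentage points higher from compound 3 to compound 4 (within the scatter) that need not exceed the scatter. The estimate for compound 4 is 8%, expected within a range from -5% to 28%.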

Compound 4, a percentage reported as inhibition, at one concentration (the size of the read-out at that concentration, not a potency): 0%
Compound 4: middle estimate off by 8 percentage points, on the high side; the range from low to high includes it.
By their numbers in this assay, from the lowest: compounds 1, 4 and 3 (each within the scatter of the next); then compound 2.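

In this assay the diethylsulfamoyl group joins the low readings at this aromatic carbon, with a number 1 percentage points lower from compound 3 to compound 4 (within the scatter) and no change at the digits printed from compound 1 to compound 4 (within the scatter), whereas the step from the thiazole of compound 2 is large, with a number 32 percentage points lower from compound 2 to compound 4 (beyond the scatter). Of the four groups now seen at this position, cyano, 2-methyl-1,3-thiazol-4-yl and diethylsulfamoyl read alike, with and without a ring, and only the 1,3-thiazol-2-yl of compound 2 stands apart. Nothing available explains why this one group differs from the other three.

Going by these compounds, it remains open whether the reading of compound 2 depends on the thiazole's point of attachment, on the absence of the methyl group, or on both. On these data alone, it is also open whether an amine, a carboxylic acid or a plain phenyl at this aromatic carbon would raise the read-out.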